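Swapping hydroxy for amino on two triazole cores

The source may hold more compounds than are shown below. What is called first, only, known or untested is meant among the compounds shown, and "the series" means these compounds.

Measured so far:
Compound 1, `COc1ccc(Cn2nncc2-c2cc(OC)c(OC)c(OC)c2)cc1O`: 1830 nM
Compound 2, `COc1ccc(Cn2nncc2-c2cc(OC)c(OC)c(OC)c2)cc1N`: 730 nM
Compound 3, `COc1ccc(-c2cn(Cc3cc(OC)c(OC)c(OC)c3)nn2)cc1O`: > 10000 nM

In a functional assay on K562 cells (Homo sapiens) for cytotoxicity, read by MTT assay, with a stated time of 5 days (a higher number here means a weaker inhibitor, a lower number a stronger inhibitor), compound 1 gives 1830 nM, and compound 2 gives 730 nM. The two differ by one change, (amino in place of hydroxy on an aromatic carbon), and that change gave a 2.5-fold lower number from compound 1 to compound 2 (0.40 log units; beyond the scatter). Compound 3 has the same atoms as compound 1 joined differently; the difference between the two cores is not broken down here. For compound 3 the result in this assay is a limit, > 10000 nM, as given by the limit of > 10000 nM in this assay, at which 1 of the 3 values shown sits. Compound 4, `COc1ccc(-c2cn(Cc3cc(OC)c(OC)c(OC)c3)nn2)cc1N`, is not yet measured; it differs from compound 3 by amino in place of hydroxy on an aromatic carbon, the same change as between compound 1 and compound 2. From compound 3 to compound 4 a step like a number no higher from compound 3 to compound 4 (the limit leaves the size open) is expected, resting on the step of a 2.5-fold lower number from compound 1 to compound 2 (0.40 log units; beyond the scatter). Compound 4 is therefore estimated at 10000 nM in this assay, within 3000 nM to 30000 nM.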

Compound 4, half-maximal inhibitory concentration: > 10000 nM
Compound 4 was reported as a limit (the forecaster's own chance of this, stated with the estimate: 60%); the middle value lies on the limit itself.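

Compound 3 and compound 4 both stand as limits, so no step between them can be read: the limit of > 10000 nM in this assay, at which 2 of the 4 values shown sit.

From the compounds shown here alone, whether amino in place of hydroxy changes the number on the core of compound 3 stays open.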